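A few compounds are considered here, and "the series" means these few. Any claim that something is new, unique, unknown or untested is made for them only; others in the source may bear on it.

Working notes on a set of phenylethyl ureas, all sharing an alpha-methylbenzyl urea core and differing in the substituent on the anilide ring. Compound 1 `C[C@H](NC(=O)Nc1cccc(C(F)(F)F)c1)c1ccccc1` carries a trifluoromethyl group; compound 2 `C[C@@H](NC(=O)Nc1ccc(C(F)(F)F)cc1)c1ccccc1` carries the same group on a different position of the ring, and the difference between the two cores is not broken down here. Compound 3 `CCOC(=O)c1cccc(NC(=O)N[C@@H](C)c2ccccc2)c1` and compound 4 `CCOC(=O)c1ccc(NC(=O)N[C@H](C)c2ccccc2)cc1` replace the trifluoromethyl with an ethoxycarbonyl group, compound 3 from the core of compound 1 and compound 4 from the core of compound 2.

In an ADME assay on the whole organism with Oryza sativa as the target, tested at 0.1 uM (a higher number here means a weaker effect of the compound at the concentration tested, a lower number a stronger effect), compound 1 gives 94%, compound 2 gives 93% and compound 3 gives 100%. All three numbers sit within the usual scatter of one another, so no order among them is claimed.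

The change from compound 1 to compound 3 is ethoxycarbonyl in place of trifluoromethyl on an aromatic carbon, and in this assay it made a step of a number 6 percentage points higher from compound 1 to compound 3 (within the scatter). The change from compound 2 to compound 4 is ethoxycarbonyl in place of trifluoromethyl on an aromatic carbon. It is the same kind of change, but not the same: in compound 3 the entering group sits meta to a large group, whereas in compound 4 it sits para to a large group.

For compound 4 a step of a number 5 percentage points higher from compound 2 to compound 4 (within the scatter) in this assay is expected, resting on compound 3, whose step a number 6 percentage points higher from compound 1 to compound 3 (within the scatter) stayed within the scatter, and on the value of compound 2, 93%. Compound 4 is therefore estimated at 98%, with a plausible range from 90% to 100%.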

Compound 4, a percentage reported as activity, at one concentration (the size of the read-out at that concentration, not a potency): 101%
Compound 4: the middle estimate sits 3 percentage points below what was measured, and the stated range ends below it.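

On the core of compound 2, ethoxycarbonyl in place of trifluoromethyl gives a step in this assay of a number 8 percentage points higher from compound 2 to compound 4 (within the scatter). Set beside the same change on the core of compound 1, the step shows no difference between the two cores, so in this small set the change carries from one core to the other without a measurable dependence on the core: the same change on two cores in this assay, a number 6 percentage points higher (within the scatter) from compound 1 to compound 3 and a number 8 percentage points higher (within the scatter) from compound 2 to compound 4, 2 percentage points apart, within the scatter of two such steps. Within the data shown here, this does not show that the change has any effect of its own in this assay, since neither step leaves the scatter, and the agreement between the two cores is therefore agreement between two steps that cannot be told from no step at all, read at a single concentration and on only two cores.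

The compounds shown leave open whether any substituent on this aromatic carbon moves the read-out beyond the scatter, as trifluoromethyl and ethoxycarbonyl are the only two groups compared here. An amine, a carboxylic acid or an ester with a longer chain at the same place would test whether the read-out in this assay responds to this position at all, and whether any such response would carry between the two cores.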